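Furan for pyrazole in an antiproliferative diarylamine series

This account rests on a few compounds, and the source may have more. Where it says the series, first, only, none or still open, it means among the compounds named here.

Compound 1 `CCN(c1ccc(C#N)c(Cl)c1)c1cc(-c2ccnn2C)ccc1C` gives 4330 nM in a functional assay on CWR22R cells (Homo sapiens) for antiproliferative activity, read by CCK-8 assay, with a stated time of 6 days (on this read-out lower numbers stand for stronger inhibition and higher numbers for weaker inhibition), the lower of the two numbers recorded so far; compound 2 `CCN(c1cccc(-n2ccnc2)c1)c1ccc(C#N)c(C(F)(F)F)c1` gives 19000 nM in this assay, a gap beyond the scatter. Compound 3 `CCN(c1ccc(C#N)c(Cl)c1)c1cc(-c2ccoc2)ccc1C` carries a single change from compound 1: furan-3-yl in place of 1-methyl-1H-pyrazol-5-yl on an aromatic carbon. Within the data shown here, no pair of measured compounds shows a step of this kind, so nothing here fixes its direction. A small step is expected, a 1.2-fold higher number from compound 1 to compound 3 (0.06 log units; within the scatter), with no clear movement beyond the scatter. Compound 3 is therefore estimated at 5000 nM in this assay, within a range of 2000 nM to 15000 nM.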

Compound 3, half-maximal inhibitory concentration: > 30000 nM
Compound 3: no number, only a limit; the forecaster's own chance of this, stated with the estimate: 5%; middle value at least 6.0-fold (0.77 log units) away from the limit.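

Furan-3-yl in place of 1-methyl-1H-pyrazol-5-yl gives an at least 6.9-fold higher number from compound 1 to compound 3 (0.84 log units; beyond the scatter) in this assay, the first sign that the five-membered ring at this position cannot be exchanged freely. From the compounds shown here alone, compound 3 gives > 30000 nM, which is a limit of the assay and not a number, so the full size of the step stays unknown: the limit of > 30000 nM in this assay, at which 1 of the 3 values shown sits.

The compounds shown do not separate the part played by the ring nitrogens from that of the ring methyl group. Also open, going by these compounds, is how a carboxylic acid or a dimethylamino group at this place would compare with compound 1.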